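The compounds below may be only part of what the source reports. "The series", "measured", "known", "first", "only" and "open" are said of these compounds alone.

Of the compounds shown here, three have been measured in a functional assay on SiHa cells (Homo sapiens) for cytotoxicity, read by MTT assay, with a stated time of 48 h; on this read-out lower numbers stand for stronger inhibition and higher numbers for weaker inhibition. Compound 1 `CCCCCCCCNC(=O)[C@@H](NC(=O)c1nccc2ccccc12)[C@@H](C)O` gives 66000 nM, compound 2 `CCCCCCCCCCCCNC(=O)[C@@H](NC(=O)c1ccco1)[C@@H](C)O` gives 64300 nM, and compound 3 `CCCCCCCCCCCCNC(=O)[C@@H](NC(=O)c1cc2ccccc2o1)[C@@H](C)O` gives 12900 nM. Compound 3 therefore stands lowest of the three numbers, that is, strongest on this read-out, and each of the other two compounds lies beyond the scatter from it. Within the data shown here, the only step that can be traced within these three is a 5.0-fold lower number from compound 2 to compound 3 (0.70 log units; beyond the scatter), the exchange of one aromatic group for another on the carbonyl carbon. Compound 4 `CCCCCCCCCCCCNC(=O)[C@@H](NC(=O)c1nccc2ccccc12)[C@@H](C)O` takes a further step of the same kind from compound 3: isoquinolin-1-yl in place of 1-benzofuran-2-yl on a carbonyl carbon. That earlier step says nothing direct about isoquinolin-1-yl. Among the measured compounds shown here, compound 1, which already carries isoquinolin-1-yl but on a shorter chain, gives 66000 nM, a weak number, and no single step links compound 1 to compound 4. Compound 4 is therefore expected to fall between these cases, with a 2.3-fold higher number from compound 3 to compound 4 (0.37 log units; beyond the scatter) toward weaker inhibition, an estimated 30000 nM and a range from 8000 nM to 100000 nM.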

Compound 4, half-maximal inhibitory concentration: 56600 nM
Compound 4: the middle estimate sits 1.9-fold (0.28 log units) below what was measured; low and high end bracket the measured number.
By their numbers in this assay, from the lowest: compound 3; then compounds 4, 2 and 1 (each within the scatter of the next).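

In this assay, the gain seen with 1-benzofuran-2-yl does not carry over to every two-ring aromatic group on this carbonyl carbon: isoquinolin-1-yl gives a 4.4-fold higher number from compound 3 to compound 4 (0.64 log units; beyond the scatter). The two-ring size alone therefore does not set the result, and the comparison with the one-ring furan-2-yl gives a 1.1-fold lower number from compound 2 to compound 4 (0.06 log units; within the scatter), so these two groups cannot be told apart on the longer chain. With isoquinolin-1-yl in place, adding butyl to the chain gives a 1.2-fold lower number from compound 1 to compound 4 (0.07 log units; within the scatter), so this chain change has no readable effect in this pair.

No measured evidence here explains why 1-benzofuran-2-yl stands apart from isoquinolin-1-yl. Still open, as far as these compounds go, are whether the same chain change would matter with 1-benzofuran-2-yl in place, and what an amine on the isoquinolin-1-yl ring would give.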